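Small step on a ring of compound 3

A few compounds are considered here, and "the series" means these few. Any claim that something is new, unique, unknown or untested is made for them only; others in the source may bear on it.

Compound 1 `COc1cc(/C=C/C(=O)C(=Cc2ccc(OC)c(OC)c2)C(=O)/C=C/c2ccc(O)c(OC)c2)ccc1O` gives 6760 nM
Compound 2 `COc1cc(/C=C/C(=O)C(=Cc2ccccc2)C(=O)/C=C/c2ccc(O)c(OC)c2)ccc1O` gives 8580 nM
Compound 3 `CCOc1cc(/C=C/C(=O)C(=Cc2ccc(O)c(OC)c2)C(=O)/C=C/c2ccc(O)c(OCC)c2)ccc1O` gives 5360 nM
Compound 4 `CCOc1cc(/C=C/C(=O)C(=Cc2ccc(O)c(O)c2)C(=O)/C=C/c2ccc(O)c(OCC)c2)ccc1O` awaits measurement

In a functional assay, read by spectrophotometry, with a stated time of 5 min (on this read-out lower numbers stand for stronger inhibition and higher numbers for weaker inhibition), compound 3 gives 5360 nM and lies within the scatter of both compound 1 and compound 2, so these three cannot be ranked. Compound 4 differs from compound 3 in one place: hydrogen in place of methyl on an oxygen on an aromatic ring, turning 4-hydroxy-3-methoxyphenyl into 3,4-dihydroxyphenyl. Among the measured compounds shown here, the only measured step involving a change on this ring, a 1.3-fold higher number from compound 1 to compound 2 (0.10 log units; within the scatter), put phenyl in place of 3,4-dimethoxyphenyl and stayed within the scatter. No measurement covers this exact change, so the expectation is uncertain. The step expected in this assay is a 1.1-fold lower number from compound 3 to compound 4 (0.05 log units; within the scatter), nothing beyond the scatter. For compound 4 the estimated value is 4800 nM, with an expected range from 2400 nM to 9500 nM.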

Compound 4, half-maximal inhibitory concentration: 3630 nM
Compound 4: middle estimate off by 1.3-fold (0.12 log units), on the high side, within the range that was stated.
By their numbers in this assay, from the lowest: compounds 4, 3, 1 and 2 (each within the scatter of the next, the first and the last beyond it).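

Replacing the methyl on an oxygen with hydrogen, which turns 4-hydroxy-3-methoxyphenyl into 3,4-dihydroxyphenyl, gives a 1.5-fold lower number from compound 3 to compound 4 (0.17 log units; within the scatter) in this assay. The earlier step swapped a whole substituted ring for phenyl, whereas this one shows that a change of a single group on this ring also leaves the number within the scatter. Nothing available explains this small step.

The compounds shown leave open whether an amine or a carboxylic acid in place of this hydroxy group would move the number beyond the scatter.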